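The source may hold more compounds than are shown below. What is called first, only, known or untested is meant among the compounds shown, and "the series" means these compounds.

Measured in an ADME assay on HOS cells (Homo sapiens) for cytotoxicity; on this read-out lower numbers stand for higher toxicity in this test and higher numbers for lower toxicity in this test:
- compound 1 `CN1CCCC(Cn2c(CN(C)C3CCCc4cccnc43)nc3ccccc32)C1`: 3000 nM
- compound 2 `CN1CCC[C@H](Cn2c(CN(C)[C@H]3CCCc4cccnc43)nc3ccccc32)C1`: 3600 nM

In this assay compound 2 gives 3600 nM, which lies within the scatter of compound 1 at 3000 nM. The next structure is compound 3 `CC(C)CCN1CCC[C@H](Cn2c(CN(C)[C@H]3CCCc4cccnc43)nc3ccccc32)C1`, and its difference from compound 2 is this: isobutyl in place of hydrogen on a saturated chain carbon bound to an amine nitrogen in a ring. Within the data shown here, the only measured step, a 1.2-fold higher number from compound 1 to compound 2 (0.08 log units; within the scatter), stays within the scatter and concerns only (the fact that one of compounds 1 and 2 is drawn with a defined configuration and the other without, at the place where they differ). It involves no added group, so it gives no direct guide to the size or direction of this change. No step beyond the scatter is therefore expected in this assay, although the uncertainty is wide. The expected outcome is a 1.2-fold lower number from compound 2 to compound 3 (0.08 log units; within the scatter). For compound 3 the estimated value is 3000 nM, with an expected range from 800 nM to 11000 nM.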

Compound 3, half-maximal cytotoxic concentration: 2300 nM
Compound 3: middle estimate off by 1.3-fold (0.12 log units), on the high side; the range from low to high includes it.
By their numbers in this assay, from the lowest: compounds 3, 1 and 2 (each within the scatter of the next).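

In this assay the change from 1-methylpiperidin-3-yl to 1-isopentylpiperidin-3-yl gives a 1.6-fold lower number from compound 2 to compound 3 (0.19 log units; within the scatter) and so offers the only reading shown for a group added at this place. It shows that isobutyl, with its 4 heavy atoms and no ring, can stand on a saturated chain carbon bound to an amine nitrogen in a ring without a step beyond the scatter on this read-out. Nothing on hand bears on the reason for the size of this step.

From the compounds shown here alone, how a longer chain, a benzyl group or a carboxylic acid at the same place would read in this assay remains open. So does whether any group there could move the number beyond the scatter, in either direction.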